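The source may hold more compounds than are shown below. What is called first, only, known or untested is meant among the compounds shown, and "the series" means these compounds.

Measured in a functional assay on HL60/MX2 cells (Homo sapiens) for antiproliferative activity, read by MTT assay, with a stated time of 48 h; on this read-out lower numbers stand for stronger inhibition and higher numbers for weaker inhibition:
Compound 1 `Cn1c(N)c(-c2nc3ccccc3[nH]2)c2nc(C#N)c(C#N)nc21`: > 50000 nM
Compound 2 `CCN(CC)CCn1c(N)c(-c2nc3ccccc3n2C)c2nc(C#N)c(C#N)nc21`: 3250 nM
Compound 3 `CN(C)CCCCn1c(-c2c(N)n(C)c3nc(C#N)c(C#N)nc23)nc2ccccc21`: 2810 nM

The entry for compound 1 is a limit of the assay, not a number. Compound 3 and compound 2 lie within the scatter of each other. Within the data shown here, the one measured step, an at least 17-fold lower number from compound 1 to compound 3 (1.25 log units; beyond the scatter), came with placing 4-(dimethylamino)butyl on an aromatic nitrogen. Compound 4 `CCN(CC)CCCCn1c(-c2c(N)n(C)c3nc(C#N)c(C#N)nc23)nc2ccccc21` keeps that chain but ends in diethylamino in place of dimethylamino (diethylamino in place of dimethylamino on a saturated chain carbon, four bonds along the chain from an aromatic nitrogen). Compound 2, at 3250 nM, also carries diethylamino, and its number stays within the scatter of that of compound 3. The large step therefore concerns gaining the chain, not changing its end. The expected change in this assay is a 1.0-fold lower number from compound 3 to compound 4 (0.00 log units; within the scatter), which means no expected step beyond the scatter. For compound 4 the estimate is 2800 nM, with an expected range of 1200 nM to 6500 nM.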

Compound 4, half-maximal inhibitory concentration: 3920 nM
Beside the measured number, compound 4's estimate is 1.4-fold (0.15 log units) below it, within the range that was stated.
By their numbers in this assay, from the lowest: compounds 3, 2 and 4 (each within the scatter of the next). At a limit, above all of these: compound 1.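

In this assay, diethylamino in place of dimethylamino at the end of the butyl chain gives a 1.4-fold higher number from compound 3 to compound 4 (0.14 log units; within the scatter), so the two chain ends cannot be told apart here. With the diethylamino end, adding the chain still gives an at least 12-fold lower number from compound 1 to compound 4 (1.10 log units; beyond the scatter), so the large step seen earlier does not depend on dimethylamino. That step starts from a limit of the assay, not a number: the limit of > 50000 nM in this assay, at which 1 of the 4 values shown sits.

The compounds shown leave open whether a ring amine such as piperidine or morpholine at the chain end would keep this level. They also leave open what a carboxylic acid in place of the amine would do.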